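The source may report more compounds than this note shows. Statements on the series, on what has been measured and on what is new or still open speak of the compounds shown alone.

Compound 1 `O=C(Nc1cccc(/C=C/C(=O)c2nc3ccccc3[nH]2)c1)c1ccc(Cl)cc1`: 8410 nM
Compound 2 `COc1ccc(C(=O)Nc2cccc(/C=C/C(=O)c3nc4ccccc4[nH]3)c2)cc1`: 20100 nM
Compound 3 `O=C(/C=C/c1cccc(NS(=O)(=O)c2ccccc2Cl)c1)c1nc2ccccc2[nH]1`: 4280 nM

All three were tested in a functional assay on MCF7 cells (Homo sapiens) for antiproliferative activity, read by MTT assay, with a stated time of 48 h; on this read-out higher numbers stand for weaker inhibition and lower numbers for stronger inhibition. Compound 3 gives the lowest of the three numbers, yet a 2.0-fold lower number from compound 1 to compound 3 (0.29 log units; within the scatter) stays within the scatter, so only compound 2 is clearly set apart, as a 4.7-fold lower number from compound 2 to compound 3 (0.67 log units; beyond the scatter) shows. Compound 4 `Cc1cccc(S(=O)(=O)Nc2cccc(/C=C/C(=O)c3nc4ccccc4[nH]3)c2)c1` differs from compound 3 in one place: 3-methylphenyl in place of 2-chlorophenyl on a sulfonyl sulfur. For the measured compounds named here, no measured step exchanges one group for another on this sulfonyl-linked ring. The nearest comparison is a 2.4-fold higher number from compound 1 to compound 2 (0.38 log units; beyond the scatter), which concerns a different group elsewhere on the shared core and moved the number only modestly. Compound 4 is therefore expected to stay close to compound 3, with an estimated step of a 1.3-fold higher number from compound 3 to compound 4 (0.11 log units; within the scatter). Compound 4 is estimated at 5500 nM, with a range from 2000 nM to 15000 nM.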

Compound 4, half-maximal inhibitory concentration: 886 nM
Compound 4: the middle estimate sits 6.2-fold (0.79 log units) above what was measured; the measured number lies below the stated range.
By their numbers in this assay, from the lowest: compound 4; then compounds 3 and 1 (each within the scatter of the next); then compound 2.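

Swapping 2-chlorophenyl for 3-methylphenyl on the sulfonyl sulfur gives a 4.8-fold lower number from compound 3 to compound 4 (0.68 log units; beyond the scatter) in this assay, the first sign that this ring can move the number beyond the scatter. The (3-methylphenyl)sulfonyl group also gives a 23-fold lower number from compound 2 to compound 4 (1.36 log units; beyond the scatter) and a 9.5-fold lower number from compound 1 to compound 4 (0.98 log units; beyond the scatter), though each of these steps changes the link and its ring together. Nothing available explains the drop. Going by these compounds, whether it follows from losing the chlorine, gaining the methyl or the different ring positions stays open. How an amine or a carboxylic acid on this ring would read is also unknown.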